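Methoxymethyl for phenyl on the amide carbonyl

The source may report more compounds than this note shows. Statements on the series, on what has been measured and on what is new or still open speak of the compounds shown alone.

In a functional assay on DU-145 cells (Homo sapiens) for antiproliferative activity, read by sulforhodamine B assay, with a stated time of 3 days (a lower number here means a stronger inhibitor of growth, a higher number a weaker inhibitor of growth), compound 3 `O=C(Nc1cccc(Nc2ncc(F)c(Nc3ccc(F)cc3)n2)c1)c1ccccc1` gives > 10000 nM, which is a limit of the assay and not a number. Compound 1 `O=C(Nc1nccs1)c1cccc(Nc2ncc(F)c(Nc3ccc(F)cc3)n2)c1` gives > 10000 nM, also a limit. Among the compounds with values here, compound 2 `O=C(Nc1cccc(Nc2ncc(F)c(Nc3ccc(F)cc3)n2)c1)c1ccncc1` gives 4330 nM, the only true number so far. Compound 3 therefore stands with the majority of the series, at the limit of > 10000 nM in this assay, at which 2 of the 3 values shown sit.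

Compound 4 `COCC(=O)Nc1cccc(Nc2ncc(F)c(Nc3ccc(F)cc3)n2)c1` differs from compound 3 at a single place: methoxymethyl in place of phenyl on a carbonyl carbon. In words, methoxymethyl stands in place of phenyl on a carbonyl carbon.

The closest measured change is an at least 2.3-fold higher number from compound 2 to compound 3 (0.36 log units; beyond the scatter), made on the same carbonyl carbon. The other readable change is an at least 2.3-fold lower number from compound 1 to compound 2 (0.36 log units; beyond the scatter). Each has a limit at one end, so its true size is not known. No group without a ring has yet been measured at this place, so the direction is poorly fixed. A modest fall in the number is expected at most, with a result near the limit equally plausible. This expectation is guided by compound 2, which gives 4330 nM. The expected change is an at least 1.1-fold lower number from compound 3 to compound 4 (0.04 log units; that floor lies within the scatter). For compound 4 the estimated value is 9000 nM, with an expected range from 3500 nM to 20000 nM.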

Compound 4, concentration for 50% growth inhibition: 4460 nM
Estimate against measurement, compound 4: 2.0-fold (0.30 log units) above; the range from low to high includes it.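

In this assay the change on the carbonyl carbon is an at least 2.2-fold lower number from compound 3 to compound 4 (0.35 log units; beyond the scatter), so a ring is not required at this place for a measurable value, and the open chain of methoxymethyl is enough. Against the other amide that gives a true number, the change is a 1.0-fold higher number from compound 2 to compound 4 (0.01 log units; within the scatter), so methoxymethyl and pyridin-4-yl cannot be told apart at this place, while phenyl remains at a limit of the assay. The change from the reversed arrangement is an at least 2.2-fold lower number from compound 1 to compound 4 (0.35 log units; beyond the scatter), which places compound 4 with compound 2 and apart from the (1,3-thiazol-2-yl)carbamoyl compound.

As far as these compounds go, compound 1 and compound 3 both remain at a limit, so the step between them cannot be read and neither true value is known: the limit of > 10000 nM in this assay, at which 2 of the 4 values shown sit. Whether the ether oxygen of methoxymethyl matters stays open, since a plain ethyl group on the same carbonyl carbon would be needed to tell, and so does whether a longer chain ending in an amine or a carboxylic acid would take the number lower than the values seen so far.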